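The source may report more compounds than this note shows. Statements on the series, on what has been measured and on what is new or still open speak of the compounds shown alone.

Compound 2, `OC[C@H]1O[C@@H](n2cnc3c(CSc4ccccc4Br)ncnc32)[C@H](O)[C@@H]1O`, is measured in an assay on isolated protein for binding affinity to Equilibrative nucleoside transporter 1 (Homo sapiens) (a lower number here means a stronger inhibitor, a higher number a weaker inhibitor), at 2400 nM. Among the compounds with values here, its only companion, compound 1, `OC[C@H]1O[C@@H](n2cnc3c(SCC4CCCCC4)ncnc32)[C@H](O)[C@@H]1O`, gives 1550 nM in this assay, and the single step between the two, a 1.5-fold higher number from compound 1 to compound 2 (0.19 log units; within the scatter), lies within the scatter, so the two numbers are best read as the same level; compound 2 thus stands at the level of the only other value shown, with nothing separating them beyond the scatter. Compound 3, `OC[C@H]1O[C@@H](n2cnc3c(CSc4ccccc4I)ncnc32)[C@H](O)[C@@H]1O`, differs from compound 2 by iodo in place of bromo on an aromatic carbon. Within the data shown here, no measured step touches this change: the step from compound 1 to compound 2 exchanges the group attached through sulfur at the other end of the molecule and leaves the halogen untouched, so it says nothing about swapping one halogen for another. Lacking any step that bears on the change, and with the one known step itself within the scatter, compound 3 is expected to stay close to compound 2, with no change at the digits printed from compound 2 to compound 3 (within the scatter) not reaching beyond the scatter. The estimate for compound 3 is therefore 2400 nM, with a range from 1100 nM to 5200 nM.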

Compound 3, half-maximal inhibitory concentration: 282 nM
Compound 3: middle estimate off by 8.5-fold (0.93 log units), on the high side; the measured number lies below the stated range.
By their numbers in this assay, from the lowest: compound 3; then compounds 1 and 2 (each within the scatter of the next).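

In this assay the halogen on this aromatic carbon, ortho to a large group, proves to matter: an 8.5-fold lower number from compound 2 to compound 3 (0.93 log units; beyond the scatter) comes from exchanging a single heavy atom, bromo for iodo, and it lies beyond the scatter. The iodo compound also separates from the compound with the non-aromatic ring, with a 5.5-fold lower number from compound 1 to compound 3 (0.74 log units; beyond the scatter) where a 1.5-fold higher number from compound 1 to compound 2 (0.19 log units; within the scatter) had left the bromo compound at the same level, so among these three the change of end group shows up only when iodo is present. Within the data shown here, nothing available explains why this one atom exchange moves the number so far.

The three compounds do not tell whether the lower number belongs to iodo alone or would also appear with chloro, methyl or methoxy on the same carbon of the phenyl ring. They also leave open whether iodo would have the same effect with a different link to the shared core, such as an oxygen or an amine in place of the sulfur.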